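Fluoro for chloro on the aryl ring: cytotoxicity notes

This account rests on a few compounds, and the source may have more. Where it says the series, first, only, none or still open, it means among the compounds named here.

Three compounds on one shared core are measured in an ADME assay on THP-1 cells (Homo sapiens) for cytotoxicity, read by MTT assay, with a stated time of 72 h; on this read-out lower numbers stand for higher toxicity in this test and higher numbers for lower toxicity in this test. Compound 1 `O[C@@H]1Cc2ccccc2N[C@H](c2ccc(Cl)cc2)C1` gives 114000 nM in this assay. Compound 2 `O[C@@H]1Cc2ccccc2N[C@H](c2ccc(F)cc2)C1` reaches only the limit of this assay, > 300000 nM, which is not a number. Compound 3 `O[C@@H]1Cc2ccccc2N[C@H](c2c(Cl)cccc2Cl)C1` likewise reaches only the limit of this assay, > 300000 nM. On these data alone, the change fluoro in place of chloro on an aromatic carbon gives an at least 2.6-fold higher number from compound 1 to compound 2 (0.42 log units; beyond the scatter), a move toward lower toxicity whose full size is unknown since the upper value is the limit of > 300000 nM in this assay, at which 2 of the 3 values shown sit. The difference between the core of compound 1 and the core of compound 3 is not broken down here.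

Compound 4 `O[C@@H]1Cc2ccccc2N[C@H](c2c(F)cccc2Cl)C1` is not yet measured in this assay. It differs from compound 3 by fluoro in place of chloro on an aromatic carbon, the same kind of change as that from compound 1 to compound 2, though not the same: here the fluoro enters ortho to a large group and meta to a chloro group, whereas in the earlier pair it entered para to a large group.

Beside the earlier step, compound 4 is expected to make a step that the limit leaves unreadable from compound 3 to compound 4, a step that can hardly be resolved, resting on an at least 2.6-fold higher number from compound 1 to compound 2 (0.42 log units; beyond the scatter), which pointed toward lower toxicity, and on (the limit of > 300000 nM in this assay, at which 2 of the 3 values shown sit), at which the starting value already sits. Compound 4 is therefore expected to give about 350000 nM in this assay, within 150000 nM to 800000 nM, and most probably once more only the limit of this assay rather than a number.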

Compound 4, half-maximal cytotoxic concentration: > 300000 nM
Compound 4: a limit, no number (the forecaster's own chance of this, stated with the estimate: 70%); the middle value lies beyond the limit too.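

In this assay compound 4 gives > 300000 nM as a limit and not a number. With compound 3 also at a limit, no step can be read between compound 3 and compound 4: the limit of > 300000 nM in this assay, at which 3 of the 4 values shown sit. The compounds shown leave open whether fluoro in place of chloro on an aromatic carbon moves the number on the core of compound 3 in the direction seen from compound 1 to compound 2.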